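The source may hold more compounds than are shown below. What is called first, only, known or untested is meant among the compounds shown, and "the series" means these compounds.

Of the compounds shown here, two built on a shared core have been measured in an assay on HeLa cells for binding affinity to 5-hydroxytryptamine receptor 6 (Homo sapiens); a higher number here means a weaker inhibitor, a lower number a stronger inhibitor. Compound 1, `COc1ccc(NS(=O)(=O)c2cn(C)cn2)cc1N1CCN(C)CC1`, gives 794 nM in this assay. Compound 2, `COc1ccc(NS(=O)(=O)c2ccc3c(Cl)cccc3c2)cc1N1CCN(C)CC1`, gives 0.794 nM in this assay. Of these two numbers, compound 1 has the higher one, and its gap to compound 2 lies far beyond the usual scatter of repeated measurements, so compound 1 is clearly the weaker inhibitor of the pair.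

Compound 3, `COc1ccc(NS(=O)(=O)c2cc(Cl)cc(Cl)c2)cc1N1CCN(C)CC1`, has not yet been measured. It is derived from compound 1 by a single change: 3,5-dichlorophenyl in place of 1-methyl-1H-imidazol-4-yl on a sulfonyl sulfur. A five-membered aromatic ring with hetero atoms leaves, and a six-membered aromatic ring of carbon only, bearing chlorine, enters on the sulfonyl sulfur.

Going by the values given here, no pair of measured compounds shows exactly this exchange. Compound 2, which carries a different group on that sulfur, gives 0.794 nM. On that basis compound 3 is expected to move toward a lower number, by a step of a 99-fold lower number from compound 1 to compound 3 (2.00 log units; beyond the scatter) that should lie beyond the scatter. Compound 3 is estimated at 8 nM, within a range from 1 nM to 60 nM.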

Compound 3, inhibition constant: 2 nM
Beside the measured number, compound 3's estimate is 4.0-fold (0.60 log units) above it; low and high end bracket the measured number.
By their numbers in this assay, from the lowest: compound 2; then compound 3; then compound 1.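

In this assay, going by these compounds alone, the exchange on the sulfonyl sulfur now has a directly measured effect: 3,5-dichlorophenyl in place of 1-methyl-1H-imidazol-4-yl gives a 400-fold lower number from compound 1 to compound 3 (2.60 log units; beyond the scatter), a large step and the first comparison here in which only this one group differs. Within the data shown here, compound 3 gives 2 nM and compound 2 gives 0.794 nM, so a single-digit or lower nanomolar reading at this position is not tied to the one group carried by compound 2. The exchange alters several things at once, replacing a five-membered aromatic ring with hetero atoms by a six-membered aromatic ring of carbon only that bears chlorine, and nothing in the available data identifies which of these alterations produces the step.

The compounds shown leave open how much of the step comes from the ring and how much from the chlorine atoms, a question that a plain phenyl, a phenyl with one chlorine, or a phenyl carrying an amine or a carboxylic acid instead of chlorine could address. They also leave open whether the same exchange would have a similar effect on a different core.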